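Trifluoromethyl for Methoxy on a Thiophene Ester Series

This account rests on a few compounds, and the source may have more. Where it says the series, first, only, none or still open, it means among the compounds named here.

Compound 1 `COc1cccc(-c2csc(N)c2C(=O)OCc2ccccc2)c1`: 57%
Compound 2 `COc1ccc(-c2csc(N)c2C(=O)OCc2ccccc2)cc1`: 86%
Compound 3 `Nc1scc(-c2cccc(C(F)(F)F)c2)c1C(=O)OCc1ccccc1`: 29%

Three compounds were measured in an assay on isolated protein for inhibition of protein kinase C zeta type (Homo sapiens), with stated times of 1 h and 2.5 min, tested at 30 uM; on this read-out higher numbers stand for more inhibition at the one concentration tested (going by the name of the read-out) and lower numbers for less inhibition. The core of compound 1 and that of compound 2 differ as follows: 4-methoxyphenyl in place of 3-methoxyphenyl on an aromatic carbon. That change gave a number 29 percentage points higher from compound 1 to compound 2 (beyond the scatter). Compound 3 differs from compound 1 in one place: trifluoromethyl in place of methoxy on an aromatic carbon. That change gave a number 28 percentage points lower from compound 1 to compound 3 (beyond the scatter), so in this assay compound 3 gives 29%.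

Compound 4 `Nc1scc(-c2ccc(C(F)(F)F)cc2)c1C(=O)OCc1ccccc1` has not been measured. It differs from compound 2 in the following way: trifluoromethyl in place of methoxy on an aromatic carbon. Within the data shown here, this is the same kind of change as the one from compound 1 to compound 3, but not the same: there the place is meta to a large group, here it is para to a large group. Whether the para position behaves like the meta one for this change is not shown by the data.

For compound 4 the expected step is a number 30 percentage points lower from compound 2 to compound 4 (beyond the scatter), resting on compound 3, because a number 28 percentage points lower from compound 1 to compound 3 (beyond the scatter). The expected value for compound 4 is 56%, estimated between 30% and 78%.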

Compound 4, a percentage reported as inhibition, at one concentration (the size of the read-out at that concentration, not a potency): 21%
Beside the measured number, compound 4's estimate is 35 percentage points above it; the whole stated range lies above it.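

In this assay, putting trifluoromethyl in place of methoxy on the core of compound 2 gave a number 65 percentage points lower from compound 2 to compound 4 (beyond the scatter), a large loss of inhibition at the one concentration tested. Among these compounds, the same change therefore lowered the number on both cores, but the size of the loss did not carry over from one core to the other: the same change on two cores in this assay, a number 28 percentage points lower (beyond the scatter) from compound 1 to compound 3 and a number 65 percentage points lower (beyond the scatter) from compound 2 to compound 4, 37 percentage points apart, beyond the scatter of two such steps What this does not show is why the two steps differ, or how large the step would be on any further core, as there are only two such pairs and the group sits in a different place on each.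

The compounds shown leave open whether another group in this place, such as a chlorine atom, an amine or a carboxylic acid, would keep the number seen for compound 2 or lose it as trifluoromethyl did. All of them also carry the same ester, so what an amide there would do remains an open question.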